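Trimming the Amine Chain Toward a Free Hydroxyl

The source may hold more compounds than are shown below. What is called first, only, known or untested is meant among the compounds shown, and "the series" means these compounds.

Measured so far:
compound 1, `O=C(/C=C(/C=C/c1ccc(O)cc1)NCCCO)/C=C/c1ccc(O)cc1`: 91.7%
compound 2, `COCCNC(=C\C(=O)/C=C/c1ccc(O)cc1)/C=C/c1ccc(O)cc1`: 89.7%

The two measured compounds share one core and differ only in the chain carried by the amine nitrogen. In a functional assay on Caco-2 cells (Homo sapiens) for activation, read by fluorescence, tested at 10 uM (on this read-out lower numbers stand for a stronger effect and higher numbers for a weaker effect at the one concentration tested), compound 1 gives 91.7%, and in the same assay compound 2 gives 89.7%. Going by the values given here, the one step between them, a number 2 percentage points lower from compound 1 to compound 2 (within the scatter), puts a methoxy in place of a hydroxymethyl on a saturated chain carbon; the two numbers sit within the scatter of each other, so neither compound stands apart on this read-out.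

Compound 3, `O=C(/C=C(/C=C/c1ccc(O)cc1)NCCO)/C=C/c1ccc(O)cc1`, is the next member. Relative to compound 2 it carries hydrogen in place of methyl on an oxygen on a saturated carbon. Among the compounds with values here, this is a related but not identical exchange to the one measured step, which changed the chain end within the scatter. On that basis compound 3 is expected to show a number 1.3 percentage points higher from compound 2 to compound 3 (within the scatter), that is, no step beyond the scatter. The estimated value for compound 3 is 91%, in a range from 80% to 100%.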

Compound 3, a percentage reported as activity, at one concentration (the size of the read-out at that concentration, not a potency): 87.1%
For compound 3 the middle estimate is 3.9 percentage points above the measured one, and the stated range covers the measured number.
By their numbers in this assay, from the lowest: compounds 3, 2 and 1 (each within the scatter of the next).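

Compound 3 adds a comparison the earlier pair did not hold: with 2-hydroxyethyl in place of 2-methoxyethyl on the amine nitrogen, this assay gives a number 2.6 percentage points lower from compound 2 to compound 3 (within the scatter), so exchanging the methyl on that oxygen for hydrogen does not separate the two compounds. Placing hydroxy where compound 1 carries hydroxymethyl on the saturated chain carbon gives a number 4.6 percentage points lower from compound 1 to compound 3 (within the scatter), and this exchange at the chain end does not separate the two compounds either. Both exchanges thus stay within the scatter on this read-out, and no further measurement is at hand that could account for the numbers.

The compounds shown leave open whether any group at this chain end can produce a step beyond the scatter, for instance an amine, a carboxylic acid or a much longer chain on the same nitrogen. They also leave open whether the chain matters at other concentrations, as the read-out reports the size of the effect at a single concentration and not a potency.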